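Working notes: 4-nitrophenyl to 4-methylphenyl in the series

A few compounds are considered here, and "the series" means these few. Any claim that something is new, unique, unknown or untested is made for them only; others in the source may bear on it.

Values in an ADME assay on HEK293 cells (Homo sapiens) for cytotoxicity; a lower number here means a stronger inhibitor, a higher number a weaker inhibitor:
- compound 1 `CCCCCCCCCCCCCCNC(=O)[C@H](CO)/N=C/c1ccccc1Cl`: 94900 nM
- compound 2 `CCCCCCCCCCCCCCNC(=O)[C@H](CO)/N=C/c1ccc(Cl)cc1`: 77700 nM
- compound 3 `CCCCCCCCCCCCCCNC(=O)[C@H](CO)/N=C/c1ccc([N+](=O)[O-])cc1`: 49500 nM
- compound 4 `CCCCCCCCCCCCCCNC(=O)[C@H](CO)/N=C/c1ccc(C)cc1`: not yet measured

Compound 3 gives 49500 nM in this assay, a value within the scatter of those of the other two measured compounds. The next change, leading to compound 4, is methyl in place of nitro on an aromatic carbon, para to a large group.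

For the measured compounds named here, three measured steps bear on this change. The closest, with nitro in place of chloro on an aromatic carbon, is a 1.6-fold lower number from compound 2 to compound 3 (0.20 log units; within the scatter). The other two are a 1.9-fold lower number from compound 1 to compound 3 (0.28 log units; within the scatter) and a 1.2-fold lower number from compound 1 to compound 2 (0.09 log units; within the scatter). All three stay within the scatter, so the three measured compounds are not separated in this assay. Going by the values given here, no measured compound carries methyl on the ring, and the data give no direct reading for that group. No step beyond the scatter is therefore expected in this assay, and no direction is firmly indicated.

The estimated step is a 1.4-fold higher number from compound 3 to compound 4 (0.14 log units; within the scatter). For compound 4 the expected value is 68000 nM, with an estimated range of 38000 nM to 120000 nM.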

Compound 4, half-maximal inhibitory concentration: 47300 nM
For compound 4 the middle estimate is 1.4-fold (0.16 log units) above the measured one; the measured number falls inside the stated range.
By their numbers in this assay, from the lowest: compounds 4, 3, 2 and 1 (each within the scatter of the next).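

In this assay, methyl now has a direct reading on an aromatic carbon para to a large group, and it is not separated from nitro at this place (a 1.0-fold lower number from compound 3 to compound 4 (0.02 log units; within the scatter)). Methyl is also not separated from either chloro compound (a 1.6-fold lower number from compound 2 to compound 4 (0.22 log units; within the scatter); a 2.0-fold lower number from compound 1 to compound 4 (0.30 log units; within the scatter)), so all four compounds remain within the scatter of one another, and exchanging nitro for methyl leaves no readable mark in this assay. Nothing available explains why these ring changes stay so close together.

The compounds shown leave open whether a group of another kind at this place, such as an amine or a carboxylic acid, would produce a step beyond the scatter. They also leave open whether a shorter chain in place of the long chain on the amide nitrogen of the shared core, or a change to its hydroxymethyl group, would separate compounds in this read-out, since all four carry the same long chain and the same hydroxymethyl group.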